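Series notes: oxime oxygen substituent, compound 2 to compound 4

The compounds below may be only part of what the source reports. "The series", "measured", "known", "first", "only" and "open" are said of these compounds alone.

Of the compounds shown here, three of the shared core have been measured. In a functional assay (blood) for inhibition, with Homo sapiens as the target (on this read-out lower numbers stand for stronger inhibition and higher numbers for weaker inhibition), compound 1 `COC1(c2cc(F)cc(Sc3ccc4c(c3)CC/C4=N\OCC#N)c2)CCOCC1` gives 30 nM. Compound 3 `Fc1cc(Sc2ccc3c(c2)CC/C3=N\OCc2ccncc2)cc(C2CCOCC2)c1` gives 90 nM in this assay. Compound 2 `COC(=O)C(C)(C)CO/N=C(\C)c1ccc(Sc2cc(F)cc(C3CCOCC3)c2)cc1` gives 420 nM in this assay, the highest number of the three; its gap to compound 3 and its larger gap to compound 1 both lie beyond the scatter.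

Compound 4 `C/C(=N\OC(=O)N(C)C)c1ccc(Sc2cc(F)cc(C3CCOCC3)c2)cc1` has not been measured. Relative to compound 2 the change is dimethylcarbamoyl in place of 2-(methoxycarbonyl)-2-methylpropyl on an oxygen. Among the measured compounds shown here, no measured pair isolates this change, so there is no direct precedent among the three measured compounds, and the other two compounds differ from compound 2 in several places at once, so their values show only that lower numbers are reachable on this core. The group that enters is smaller than the group that leaves and both carry no charge. A modest step toward a lower number in this assay is expected for compound 4, the step from compound 2 being estimated as a 1.4-fold lower number from compound 2 to compound 4 (0.15 log units; within the scatter). Compound 4 is estimated at 300 nM, with a range from 100 nM to 1000 nM.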

Compound 4, half-maximal inhibitory concentration: 2610 nM
The estimate for compound 4 lay 8.7-fold (0.94 log units) below the measured number, and the stated range ends below it.
By their numbers in this assay, from the lowest: compound 1; then compound 3; then compound 2; then compound 4.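

On the oxygen whose other neighbour is the double-bonded nitrogen, dimethylcarbamoyl in place of 2-(methoxycarbonyl)-2-methylpropyl gives a 6.2-fold higher number from compound 2 to compound 4 (0.79 log units; beyond the scatter) in this assay and so shows that inhibition responds to the group at this position. Among the compounds shown here, this is the first step that isolates the oxime oxygen substituent. It runs toward weaker inhibition although the entering group is the smaller by heavy-atom count, so on this pair a smaller group does not bring a lower number. Nothing at hand bears on what lies behind this step.

On these data alone, it remains open whether the rise follows from the carbonyl attached directly to the oxygen or from the removal of the ester-bearing chain; a plain ethyl group or a 2-(dimethylamino)ethyl chain on the same oxygen would separate the two. As far as these compounds go, whether the step carries over to the core of compound 1 also stays open.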